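Replacing a benzyl amide with a chloroanilide

The source may hold more compounds than are shown below. What is called first, only, known or untested is meant among the compounds shown, and "the series" means these compounds.

Measured compounds:
- compound 1, `O=C(/C=C/c1coc2cc(O)ccc2c1=O)NCc1ccccc1`: > 100000 nM in a functional assay on A549 cells (Homo sapiens) for inhibition, read by MTT assay, with a stated time of 48 h; on this read-out higher numbers stand for weaker inhibition and lower numbers for stronger inhibition
- compound 2, `COc1ccc2c(=O)c(/C=C/C(=O)NCc3ccccc3)coc2c1`: 11800 nM in this assay

Going by the values given here, compound 2 holds the only numerical value in this assay. For compound 1 only a limit is known, > 100000 nM, which is a boundary of the assay rather than a measured number; compound 1 sits at the limit of > 100000 nM in this assay, at which 1 of the 2 values shown sits. Among the compounds with values here, the one measured step, an at least 8.4-fold lower number from compound 1 to compound 2 (0.92 log units; beyond the scatter), concerns a methyl in place of hydrogen on an oxygen on an aromatic ring and leaves the amide side untouched.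

Compound 3, `COc1ccc2c(=O)c(/C=C/C(=O)Nc3ccccc3Cl)coc2c1`, differs from compound 2 by 2-chlorophenyl in place of benzyl on an amide-type nitrogen. No measured step changes this position, so nothing among the shown values bears on it, and the expectation rests on the starting point alone.

Compound 3 is therefore expected to stay close to compound 2, an estimated step of a 1.2-fold lower number from compound 2 to compound 3 (0.07 log units; within the scatter), not beyond the scatter. The estimate for compound 3 in this assay is 10000 nM, with a range from 3000 nM to 40000 nM.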

Compound 3, half-maximal inhibitory concentration: 29900 nM
Estimate against measurement, compound 3: 3.0-fold (0.48 log units) below; measured number inside the range.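

The amide side is not silent: in this assay the change gives a 2.5-fold higher number from compound 2 to compound 3 (0.40 log units; beyond the scatter) and so shows that the group on this amide-type nitrogen affects inhibition, with compound 3 the weaker of the pair. Benzyl and 2-chlorophenyl have the same number of heavy atoms and each carries one six-membered aromatic ring of carbon only, yet they are not interchangeable at this position. Nothing measured among these compounds explains the weaker inhibition, so the step stands as an observation only.

The step also combines two structural differences, since the carbon linking the ring to the nitrogen goes and a chlorine arrives, so the compounds shown cannot separate the two; plain phenyl or 2-chlorobenzyl on the same nitrogen would be the groups to tell them apart. As far as these compounds go, it also remains open whether the gain seen with methyl on the oxygen of the shared core carries over to the 2-chlorophenyl amide, or how a longer chain or an amine on this nitrogen would read out.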